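Alpha-ketoamide series: truncating the amide side chain

The source may report more compounds than this note shows. Statements on the series, on what has been measured and on what is new or still open speak of the compounds shown alone.

Measured compounds:
compound 1, `O=C(CCc1ccc(Cl)cc1)C(=O)NCCCCc1ccccc1`, 631 nM
compound 2, `O=C(NCc1ccccc1)C(F)(F)C(O)CCc1ccccc1`, > 10000 nM (a limit)
compound 3, `CCOC(=O)C(F)(F)C(O)CCc1ccccc1`, > 10000 nM (a limit)

The read-out throughout is an assay on HEK-293T cells for inhibition of phospholipase A and acyltransferase 2 (Homo sapiens), with stated times of 30 min and 20 min; on this read-out lower numbers stand for stronger inhibition and higher numbers for weaker inhibition. Among the measured compounds shown here, compound 1 gives 631 nM, the only number in the set. For compound 2 the result in this assay is a limit, > 10000 nM. For compound 3 likewise the result is a limit, > 10000 nM. For the measured compounds named here, compound 1 therefore stands alone as a quantified value against (the limit of > 10000 nM in this assay, at which 2 of the 3 values shown sit), and no step between two numbers is available to gauge how far a change in structure moves potency.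

The next compound, compound 4, `CCNC(=O)C(=O)CCc1ccc(Cl)cc1`, keeps the core of compound 1 and shortens the chain on the amide side: hydrogen in place of phenethyl on a saturated chain carbon, two bonds along the chain from an amide-type nitrogen. The whole phenethyl piece is gone, leaving an ethyl amide in place of the four-carbon phenyl-terminated chain.

With nothing measured to calibrate this change, the expectation rests on compound 1 alone. Compound 4 is expected to be weaker, by a step of a 7.9-fold higher number from compound 1 to compound 4 (0.90 log units; beyond the scatter) beyond the usual scatter, with a fair chance that only a limit is returned. Compound 4 is estimated at 5000 nM, within 1500 nM to 20000 nM.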

Compound 4, half-maximal inhibitory concentration: 2510 nM
The estimate for compound 4 lay 2.0-fold (0.30 log units) above the measured number; low and high end bracket the measured number.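

In this assay, hydrogen in place of phenethyl on a saturated chain carbon, two bonds along the chain from an amide-type nitrogen, gives a 4.0-fold higher number from compound 1 to compound 4 (0.60 log units; beyond the scatter), the first measured size for any change in this series. The phenethyl piece, with its 8 heavy atoms and its six-membered aromatic ring, therefore counts at this position, yet the ethyl amide that remains still returns a number, so the full four-carbon phenyl-terminated chain is not needed for a quantified result in this series. Compound 2 and compound 3 remain limits in this assay, not numbers, and no step connects either of them to the other compounds: the limit of > 10000 nM in this assay, at which 2 of the 4 values shown sit.

From the compounds shown here alone, a single step cannot separate the contribution of chain length from that of the terminal aromatic ring, so whether the change follows one or the other stays open. A plain hexyl chain at this place would address that question, and a chain ending in an amine or a carboxylic acid would show how far the end of the chain can vary while the core of compound 1 stays unchanged.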